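Swapping a nitrile for trifluoromethyl without a measured baseline

The source may hold more compounds than are shown below. What is called first, only, known or untested is meant among the compounds shown, and "the series" means these compounds.

Compound 1 (`CC(C)(O)c1cc2c(-c3ccc(C#N)cc3)nccc2[nH]1`) offers no starting number: in an ADME assay on U2OS cells (Homo sapiens) for cytotoxicity (a higher number here means that more compound is tolerated, a lower number that less compound is tolerated), compound 1 is recorded as "not determined" (no result reported) and so has no place on the scale. Going by the values given here, two relatives that share its core give the only guidance. In this assay compound 2 (`Cc1cccc(-c2nccc3[nH]c(C(C)(C)O)cc23)c1`) gives 121000 nM as its result, and compound 3 (`CC(C)(O)c1cc2c(-c3cc(C(F)(F)F)cc(C(F)(F)F)c3)nccc2[nH]1`) gives 59800 nM as its result. Those two numbers are not far apart, although the two compounds carry different groups on the shared core.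

The compound still to be tested is compound 4 (`CC(C)(O)c1cc2c(-c3ccc(C(F)(F)F)cc3)nccc2[nH]1`). Among the compounds with values here, the one structural change (trifluoromethyl in place of cyano on an aromatic carbon) puts trifluoromethyl in place of cyano on an aromatic carbon, para to a large group. Within the data shown here, no measured pair shows what this swap does, so any forecast for this assay is indirect. No step beyond the scatter is expected in either direction. Compound 3 also carries trifluoromethyl and gives 59800 nM, compound 2 gives 121000 nM, and together these two results mark the region where a new number would be expected to fall. The value for compound 4 is estimated at 80000 nM with an expected range from 35000 nM to 160000 nM in this assay.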

Compound 4, half-maximal cytotoxic concentration: 72300 nM
For compound 4 the middle estimate is 1.1-fold (0.04 log units) above the measured one; the range from low to high includes it.
By their numbers in this assay, from the lowest: compounds 3, 4 and 2 (each within the scatter of the next, the first and the last beyond it).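

In this assay, going by these compounds alone, compound 1 stands as "not determined" (no result reported), so no step from it to compound 4 can be read. Nothing measured here offers a reason for the result of compound 4. Left open is what trifluoromethyl in place of cyano does in this assay when everything else on the shared core stays the same.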